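This account rests on a few compounds, and the source may have more. Where it says the series, first, only, none or still open, it means among the compounds named here.

Measured so far:
Compound 1 `O/N=C(/CCN1CCN(c2ccccn2)CC1)c1ccccc1Cl` gives 25 nM in a functional assay on HEK293 cells with D(4) dopamine receptor (Homo sapiens) as the target, read by FLIPR; on this read-out higher numbers stand for an effect only at larger amounts of compound and lower numbers for an effect already at smaller amounts.
Compound 2 `Cc1cccc(/C(CCN2CCN(c3ccccn3)CC2)=N/O)c1` gives 2.3 nM in this assay.

Of these two numbers, compound 2 has the lower one, so its effect appears at smaller amounts than that of compound 1, and the gap between the two values lies beyond the usual scatter of repeated measurements. Compound 3 `Cc1ccc(O)c(/C(CCN2CCN(c3ccccn3)CC2)=N/O)c1` has not yet been measured. It differs from compound 2 in a single place: hydroxy in place of hydrogen on an aromatic carbon. The hydroxy group enters ortho to a large group and para to a methyl group, so that the 3-methylphenyl of compound 2 becomes a 2-hydroxy-5-methylphenyl in compound 3. Among the compounds with values here, no measured pair of compounds shows this change, so its effect in this assay cannot be read from the data; a step of modest size in either direction, or none beyond the scatter, is what is expected. Taking the value of compound 2 as the starting point, compound 3 is expected to give about 5 nM, with a range from 1.5 nM to 20 nM. This estimate means a step of a 2.2-fold higher number from compound 2 to compound 3 (0.34 log units; beyond the scatter) in this assay.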

Compound 3, half-maximal effective concentration: 19.2 nM
Compound 3: the middle estimate sits 3.8-fold (0.58 log units) below what was measured; the measured number falls inside the stated range.
By their numbers in this assay, from the lowest: compound 2; then compounds 3 and 1 (each within the scatter of the next).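

In this assay, putting hydroxy in place of hydrogen on an aromatic carbon, ortho to a large group and para to a methyl group, brings an 8.3-fold higher number from compound 2 to compound 3 (0.92 log units; beyond the scatter) on going from 3-methylphenyl to 2-hydroxy-5-methylphenyl. Within the data shown here, this is the first sign that this position on the ring matters for the read-out: a single added heavy atom, an oxygen bringing one hydrogen-bond donor and one hydrogen-bond acceptor, is enough to shift the number beyond the usual scatter, and the shift means that more compound is needed for the same effect. Nothing available here accounts for the size or direction of this step.

Still open, from the compounds shown here alone, is whether this shift is specific to hydroxy or would also appear with another group at the same place, such as methoxy, fluorine or an amine. Among these compounds, equally open is whether the same hydroxy group would move the number in the same direction on the chlorine-bearing ring of compound 1, since only one ring has been seen to undergo this change.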